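This account rests on a few compounds, and the source may have more. Where it says the series, first, only, none or still open, it means among the compounds named here.

Measured so far in a functional assay on CHO cells for antagonist activity at adenosine receptor A2b (Homo sapiens), read by cAMP accumulation, with a stated time of 10 min; on this read-out higher numbers stand for weaker inhibition and lower numbers for stronger inhibition:

compound 1 `Nc1nc(-c2cccc(CO)c2)nc2sc(-c3ccccc3)nc12` — > 30000 nM
compound 2 `COc1cccc(-c2nc(N)c3nc(-c4ccccc4)sc3n2)c1` — > 30000 nM
compound 3 `Cc1ccc(-c2nc(N)c3nc(-c4ccccc4)sc3n2)o1` — > 30000 nM

Compound 1 stands only at a limit of this assay, not at a number. The same holds for compound 2, whose value is a limit. The same holds for compound 3, whose value is a limit. Across the series (the limit of > 30000 nM in this assay, at which 3 of the 3 values shown sit), so every one of the three shown values is a limit and no compound is placed relative to another.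

The steps that are shown all change the aryl group on the other side of the shared core: a step that the two limits leave unreadable from compound 1 to compound 2, a step that the two limits leave unreadable from compound 1 to compound 3, a step that the two limits leave unreadable from compound 2 to compound 3. None of them is readable in size, and none touches the place that changes between compound 1 and compound 4.

Compound 4 `Nc1nc(-c2cccc(CO)c2)nc2sc(-c3ccco3)nc12` differs from compound 1 by furan-2-yl in place of phenyl on an aromatic carbon. Going by the values given here, no measured step bears on this change, so no direction and no size can be read from the series for it; the only guidance is that every compound shown sits at the limit. Compound 4 is therefore expected to remain near that limit, and the step from compound 1 is estimated as a number no higher from compound 1 to compound 4 (the limit leaves the size open). For compound 4 the estimate in this assay is 30000 nM, with a range from 5000 nM to 100000 nM, and the result is expected most likely to be reported again as a limit.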

Compound 4, half-maximal inhibitory concentration: > 30000 nM
Compound 4 gave a limit, no number (the forecaster's own chance of this, stated with the estimate: 75%); the middle value sits exactly at the limit.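

In this assay compound 4 gives > 30000 nM, a limit and not a number, so no step can be read between compound 1 and compound 4. The compounds shown leave open whether any change on the shared core brings measurable inhibition, and how large any such change would be: the limit of > 30000 nM in this assay, at which 4 of the 4 values shown sit.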